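The compounds below may be only part of what the source reports. "The series", "measured", "known", "first", "only" and "open" are said of these compounds alone.

Measured compounds in an assay for inhibition of serine/threonine-protein kinase Sgk1 (Homo sapiens), with stated times of 30 min and 60 min, in the presence of a further agent that is not named here; on this read-out higher numbers stand for weaker inhibition and lower numbers for stronger inhibition:
compound 1, `Cc1n[nH]c2nc(-c3ccc(NS(=O)(=O)c4cc(Cl)ccc4F)cc3)nc(OCC3(CN)COC3)c12`: 1 nM
compound 2, `Cc1n[nH]c2nc(-c3ccc(NS(=O)(=O)c4cc(Cl)ccc4F)cc3)nc(OCC(CO)CO)c12`: 1 nM
compound 3, `Cc1n[nH]c2nc(-c3ccc(NS(=O)(=O)c4cc(Cl)ccc4F)cc3)nc(OCC3CN(C(C)C)C3)c12`: 1 nM

On these numbers both steps that end at compound 3 lie within the scatter: no change at the digits printed from compound 1 to compound 3 (within the scatter), and no change at the digits printed from compound 2 to compound 3 (within the scatter). The three compounds differ only in the saturated group carried on the oxygen on the aromatic ring of the shared core, and none of those exchanges moved the read-out, since also no change at the digits printed from compound 1 to compound 2 (within the scatter).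

Compound 4, `Cc1n[nH]c2nc(-c3ccc(NS(=O)(=O)c4cc(Cl)ccc4F)cc3)nc(OC3CC(C)(C)N(C)C(C)(C)C3)c12`, has not yet been measured. It differs from compound 3 in that (1,2,2,6,6-pentamethylpiperidin-4-yl in place of (1-isopropylazetidin-3-yl)methyl on an oxygen on an aromatic ring). The three measured steps are the only ones that bear on this change: each exchanges one saturated substituent for another at the same oxygen, a four-membered ring against a chain or against another four-membered ring, and each came out within the scatter. The entering group is not among those tried, so the measured steps do not cover it directly, but on the pattern they show the expected step in this assay is no change at the digits printed from compound 3 to compound 4 (within the scatter), none beyond the scatter. For compound 4 the estimate in this assay is 1 nM, with a range from 0.5 nM to 4 nM.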

Compound 4, half-maximal inhibitory concentration: 2 nM
The estimate for compound 4 lay 2.0-fold (0.30 log units) below the measured number; low and high end bracket the measured number.
By their numbers in this assay, from the lowest: compounds 1, 2, 3 and 4 (each within the scatter of the next).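

In this assay the exchange for 1,2,2,6,6-pentamethylpiperidin-4-yl stays within the scatter on all three readings, with a 2.0-fold higher number from compound 3 to compound 4 (0.30 log units; within the scatter) and a 2.0-fold higher number from compound 2 to compound 4 (0.30 log units; within the scatter) and also a 2.0-fold higher number from compound 1 to compound 4 (0.30 log units; within the scatter) as the printed steps. The earlier compounds shown here covered only a four-membered ring or an open chain on a methylene-linked oxygen substituent, whereas this result extends the same flat read-out to a six-membered non-aromatic ring with 11 heavy atoms, with (1,2,2,6,6-pentamethylpiperidin-4-yl)oxy standing in place of (1-isopropylazetidin-3-yl)methoxy on the aromatic ring of the shared core. No measurement at hand accounts for this flat read-out, so the result describes what the position accepts in this assay and offers no explanation for it.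

With every exchange so far inside the scatter, the compounds shown do not reveal any group at this oxygen that moves the read-out beyond it, and so they do not say which features of the substituent matter here. On these data alone, whether a carboxylic acid on a longer chain, a benzyl group, a plain methyl or the 2,2,6,6-tetramethylpiperidin-4-yl group would stay level with these four compounds remains open.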